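The source may report more compounds than this note shows. Statements on the series, on what has been measured and on what is new or still open speak of the compounds shown alone.

Compound 1 `CC#C[C@@H](CC(=O)O)c1ccc(OCc2ccc3nc(-c4ccc(OC(F)F)cc4)nn3c2)cc1`: > 99%
Compound 2 `CC#C[C@@H](CC(=O)O)c1ccc(OCc2ccc3nc(-c4c(C)cc(OCCCS(C)(=O)=O)cc4C)nn3c2)cc1`: > 99%

In an ADME assay on a cell-free system (plasma) for protein binding, using equilibrium dialysis, compound 1 gives > 99%, which is a limit and not a number. Compound 2 gives > 99%, also a limit. Every measurement so far therefore sits at one end of the scale: the limit of > 99% in this assay, at which 2 of the 2 values shown sit.

Compound 3 `CC#C[C@@H](CC(=O)O)c1ccc(OCc2ccc3nc(-c4ccc(C(C)C)cc4)nn3c2)cc1` carries isopropyl in place of difluoromethoxy on an aromatic carbon. Among the measured compounds shown here, no measured pair shows what such a swap does. Resting on (the limit of > 99% in this assay, at which 2 of the 2 values shown sit), the expected step that the limit leaves unreadable from compound 1 to compound 3 is none beyond the scatter. For compound 3 the estimate is 99.5%, with an expected range of 98.5% to 99.9%.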

Compound 3, plasma protein binding: > 99%
Compound 3 was reported as a limit (the forecaster's own chance of this, stated with the estimate: 70%); the middle value is on the limit's open side.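

Among the compounds shown here, no step from compound 1 to compound 3 can be read in this assay, because both are reported only as limits: the limit of > 99% in this assay, at which 3 of the 3 values shown sit.

The compounds shown leave open whether swapping difluoromethoxy for isopropyl changes binding at all.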